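The source may report more compounds than this note shows. Statements on the series, on what has been measured and on what is new or still open speak of the compounds shown alone.

Measured so far in a physicochemical assay for solubility, measured as kinetic solubility, at pH 6.5; on this read-out lower numbers stand for lower solubility and higher numbers for higher solubility:
compound 1 `COc1ccc(-c2ccc3nnc([C@@H](C)c4ccc5ncccc5c4)n3n2)cc1C` gives 1770 nM
compound 2 `Cc1cccc(-c2ccc3nnc([C@@H](C)c4ccc5ncccc5c4)n3n2)c1` gives 19000 nM
compound 3 `C[C@@H](c1ccc2ncccc2c1)c1nnc2ccc(-c3ccccc3C#N)nn12` gives 213000 nM

Compound 3 holds the highest number of the three in this assay and is the starting point for compound 4 `CNC(=O)c1ccc(-c2ccc3nnc([C@@H](C)c4ccc5ncccc5c4)n3n2)cc1`, which has not yet been measured. The change is 4-(methylcarbamoyl)phenyl in place of 2-cyanophenyl on an aromatic carbon and the rest of the structure stays the same. Two measured steps alter the group at this place: an 11-fold higher number from compound 2 to compound 3 (1.05 log units; beyond the scatter) and a 120-fold higher number from compound 1 to compound 3 (2.08 log units; beyond the scatter), both large. A third, an 11-fold higher number from compound 1 to compound 2 (1.03 log units; beyond the scatter), is also large. None of these compounds carries the entering group, so no step speaks to it directly. With compound 3 at 213000 nM at the top of this small range, a sizeable fall is expected in this assay rather than a further rise. The estimate is a 4.7-fold lower number from compound 3 to compound 4 (0.68 log units; beyond the scatter) as the expected step. For compound 4 the estimated value is 45000 nM (expected range 9000 nM to 200000 nM).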

Compound 4, solubility: 11000 nM
Compound 4: middle estimate off by 4.1-fold (0.61 log units), on the high side; measured number inside the range.
By their numbers in this assay, from the lowest: compound 1; then compounds 4 and 2 (each within the scatter of the next); then compound 3.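

In this assay, the change gives a 19-fold lower number from compound 3 to compound 4 (1.29 log units; beyond the scatter), so the 4-(methylcarbamoyl)phenyl group, with a hydrogen-bond donor that 2-cyanophenyl lacks, does not keep the top number held by compound 3. The same group gives a 1.7-fold lower number from compound 2 to compound 4 (0.24 log units; within the scatter), which leaves it indistinguishable from 3-methylphenyl at this place, while it gives a 6.2-fold higher number from compound 1 to compound 4 (0.79 log units; beyond the scatter); among the four compounds, 2-cyanophenyl alone stands clear of every other group. Nothing available explains these differences.

The compounds shown leave open whether the number of compound 3 follows the nitrile itself or its place on the phenyl ring, as a 4-cyanophenyl group would test. They also leave open how a carboxylic acid or a morpholine would read at this place.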